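Does 4-chlorophenyl lift compound 4 off the limit?

This account rests on a few compounds, and the source may have more. Where it says the series, first, only, none or still open, it means among the compounds named here.

Values in a functional assay on MCF7 cells (Homo sapiens) for antiproliferative activity, read by MTT assay, with a stated time of 24 h (on this read-out lower numbers stand for stronger inhibition and higher numbers for weaker inhibition), for three compounds
compound 1 `COc1ccc(-c2noc(-c3ccncc3)n2)cc1OC1CCCC1` gives > 1000000 nM as a limit
compound 2 `COc1ccc(-c2noc(C3CCCN3)n2)cc1OC1CCCC1` gives > 1000000 nM as a limit
compound 3 `COc1ccc(-c2noc(-c3cccnc3)n2)cc1OC1CCCC1` gives > 1000000 nM as a limit

Compound 3 stands at > 1000000 nM in this assay and that is a limit of the assay, not a number. Within the data shown here, it has company, since the whole set rests on the limit of > 1000000 nM in this assay, at which 3 of the 3 values shown sit, and no compound here has yet given a true number.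

Compound 4 `COc1ccc(-c2noc(-c3ccc(Cl)cc3)n2)cc1OC1CCCC1` carries 4-chlorophenyl in place of pyridin-3-yl on an aromatic carbon of a five-membered aromatic ring with 2 nitrogen and 1 oxygen (4-chlorophenyl in place of pyridin-3-yl on an aromatic carbon). The measured changes at this same place are a step that the two limits leave unreadable from compound 1 to compound 3 and also a step that the two limits leave unreadable from compound 1 to compound 2 with no size to carry forward. Among the measured compounds shown here, neither compound 1, compound 2 nor compound 3 has a ring of carbon only there, so the data offer no direct precedent for this swap. Only a modest move toward stronger inhibition is therefore expected, if any.

The expected change is an at least 1.6-fold lower number from compound 3 to compound 4 (0.22 log units; that floor lies within the scatter) in this assay and it is a rough estimate. Compound 4 is estimated at 600000 nM with an expected range from 60000 nM to 1500000 nM and it may well return only a limit again.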

Compound 4, half-maximal inhibitory concentration: 174000 nM
The estimate for compound 4 lay 3.4-fold (0.54 log units) above the measured number; measured number inside the range.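

In this assay, 4-chlorophenyl in place of pyridin-3-yl on this aromatic carbon gives an at least 5.7-fold lower number from compound 3 to compound 4 (0.75 log units; beyond the scatter), so a change at this position can bring a compound off the limit and yield a true number. The same group gives an at least 5.7-fold lower number from compound 2 to compound 4 (0.75 log units; beyond the scatter) when it replaces pyrrolidin-2-yl and an at least 5.7-fold lower number from compound 1 to compound 4 (0.75 log units; beyond the scatter) when it replaces pyridin-4-yl, so all three steps point the same way, and each gives only a floor on the true size. The steps among compound 1, compound 2 and compound 3 cannot be read, and compound 4 alone has a true number, with the other three resting on one shared limit of the assay: the limit of > 1000000 nM in this assay, at which 3 of the 4 values shown sit.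

Compound 4 differs from compound 3 in two ways at once, a ring of carbon only and an added chlorine, and a plain phenyl ring at this position would be needed to tell these two apart. Going by these compounds, whether a methoxy group or a fluorine in place of the chlorine would give a similar number also stays open, as does any change elsewhere on the shared core.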